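Ketone to ester at the furan-bearing core

The source may report more compounds than this note shows. Statements on the series, on what has been measured and on what is new or still open speak of the compounds shown alone.

Measured compounds:
- compound 1 `CC1=C(C(=O)OCc2ccccc2)C(c2ccco2)NC(=O)N1`: 887 nM
- compound 2 `CCCC(=O)C1=C(C)NC(=O)NC1c1ccco1`: 807 nM
- compound 3 `CC1=C(C(=O)CC(C)C)C(c2ccco2)NC(=O)N1`: 240 nM

All three share one core and were tested in an assay on membranes from HEK293 cells for displacement of a labelled ligand from adenosine receptor A2b (Homo sapiens), read by scintillation counting, with a stated time of 30 min; on this read-out lower numbers stand for stronger inhibition and higher numbers for weaker inhibition. Compound 3 gives the lowest number of the three; compound 2 sits a 3.4-fold lower number from compound 2 to compound 3 (0.53 log units; beyond the scatter), and compound 1 sits further off still, so compound 3 is the most potent of the set. Going by the values given here, the only single-point step recorded is a 3.4-fold lower number from compound 2 to compound 3 (0.53 log units; beyond the scatter), which comes from adding a methyl in place of hydrogen on a saturated chain carbon bound to two saturated chain carbons.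

Compound 4 `CC1=C(C(=O)OC2CCC2)C(c2ccco2)NC(=O)N1` is not yet measured. It differs from compound 3 by cyclobutyloxy in place of isobutyl on a carbonyl carbon. Among the compounds with values here, no measured step maps this change directly: compound 1, the one ester in the set, carries a benzyl group rather than a ring of four carbons, and its value only shows that an ester can sit well behind compound 3. On that thin basis the expected outcome in this assay is a move toward weaker binding, a 2.1-fold higher number from compound 3 to compound 4 (0.32 log units; beyond the scatter), though with wide uncertainty. Compound 4 is therefore estimated at 500 nM, within a range from 150 nM to 1600 nM.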

Compound 4, inhibition constant: 95.1 nM
Beside the measured number, compound 4's estimate is 5.3-fold (0.72 log units) above it, outside the stated range (below it).
By their numbers in this assay, from the lowest: compound 4; then compound 3; then compounds 2 and 1 (each within the scatter of the next).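

In this assay, a cyclobutyl ester at this carbonyl carbon outdoes both ketones shown: cyclobutyloxy in place of isobutyl gives a 2.5-fold lower number from compound 3 to compound 4 (0.40 log units; beyond the scatter) as the change, and cyclobutyloxy in place of propyl gives an 8.5-fold lower number from compound 2 to compound 4 (0.93 log units; beyond the scatter) as the change. An ester link is therefore no handicap in itself at this position, which compound 1 alone could not reveal. The ester of compound 1 goes against any simple rule that esters beat ketones here, and the group on the oxygen makes the difference: cyclobutyl in place of benzyl gives a 9.3-fold lower number from compound 1 to compound 4 (0.97 log units; beyond the scatter) while the ester link stays the same.

Nothing available explains the gain, and the data cannot separate the part played by the added oxygen from that played by the ring of four carbons. On these data alone, a cyclobutyl ketone would divide those two parts, while an ethyl ester, a cyclopentyl ester or an amide at the same carbonyl carbon remains open, so it is unknown how far this trend extends.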